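A few compounds are considered here, and "the series" means these few. Any claim that something is new, unique, unknown or untested is made for them only; others in the source may bear on it.

Measured compounds:
compound 1 `Cc1cccc(Cn2c(OC3CCN(C(=O)c4ccco4)CC3)nc3ccccc32)c1` — 68.3%
compound 2 `CC(C)CCn1c(CN2CCN(C(=O)c3ccco3)CC2)nc2ccccc21` — 42.1%
compound 3 `CC(C)CCn1c(OC2CCN(C(=O)c3ccco3)CC2)nc2ccccc21` — 30.8%

In an assay on isolated protein for inhibition of aldehyde dehydrogenase 1A1 (Homo sapiens), read by spectrophotometry, tested at 10 uM (on this read-out higher numbers stand for more inhibition at the one concentration tested (going by the name of the read-out) and lower numbers for less inhibition), compound 1 gives 68.3%, the highest of the three numbers. Its nearest neighbour is compound 2, which in this assay gives 42.1%, and the furthest is compound 3, which in this assay gives 30.8%; both gaps lie beyond the scatter. Among the measured compounds shown here, the one single-point step among the measured compounds is a number 37.5 percentage points lower from compound 1 to compound 3 (beyond the scatter), a large drop that concerns the group on the saturated chain carbon bound to the aromatic nitrogen.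

Compound 4 `Cc1cccc(Cn2c(OC3CCN(C(=O)C4CC4)CC3)nc3ccccc32)c1` keeps the 3-methylphenyl of compound 1 and instead alters the carbonyl end: cyclopropyl in place of furan-2-yl on a carbonyl carbon. For the measured compounds named here, no measured step touches this part of the molecule, so the drop seen in a number 37.5 percentage points lower from compound 1 to compound 3 (beyond the scatter) offers no guide to the direction or size of the change here. With nothing to anchor it, the expectation for compound 4 is a value somewhat under that of compound 1, with a wide range in this assay. The expected step is a number 13.3 percentage points lower from compound 1 to compound 4 (beyond the scatter), with compound 4 estimated at 55%, between 25% and 80%.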

Compound 4, a percentage reported as inhibition, at one concentration (the size of the read-out at that concentration, not a potency): 80.6%
The estimate for compound 4 lay 25.6 percentage points below the measured number, outside the stated range (above it).
By their numbers in this assay, from the lowest: compound 3; then compound 2; then compound 1; then compound 4.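

In this assay the carbonyl end of the molecule proves open to change: with the 3-methylphenyl group kept, cyclopropyl in place of furan-2-yl on a carbonyl carbon gives a number 12.3 percentage points higher from compound 1 to compound 4 (beyond the scatter), a modest gain. The furan-2-yl group, with its five-membered aromatic ring and its hydrogen-bond acceptor, is therefore not needed for inhibition at the one concentration tested, since a three-membered ring of carbon only, with fewer heavy atoms and no acceptor, does at least as well on this core. No measurement here explains why the smaller group gives the higher number.

The step changes ring size, aromaticity and the acceptor all at once, so the compounds shown cannot say which of these matters, and groups such as cyclobutyl, phenyl or a plain methyl on the same carbonyl carbon would be needed to separate them. On these data alone, it also stays open whether the cyclopropyl gain carries over to the isobutyl side of the series, and how it would read as a potency rather than as inhibition at a single concentration.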